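Cytotoxicity notes on a diaryl triazine series

The source may hold more compounds than are shown below. What is called first, only, known or untested is meant among the compounds shown, and "the series" means these compounds.

The series rests on a shared core carrying two aryl amine groups, with the third position varied. Compound 1, `Cc1ccc(Nc2nc(NCC3CCCO3)nc(Nc3ccc(C)cc3)n2)cc1`, carries a tetrahydrofuranylmethylamino group there; in an ADME assay on TZM cells (Homo sapiens) for cytotoxicity, with a stated time of 48 h (on this read-out higher numbers stand for lower toxicity in this test and lower numbers for higher toxicity in this test), compound 1 gives > 50000 nM; > 50000 nM; > 50000 nM; > 50000 nM (4 entries) in each of its four entries. Among the compounds with values here, compound 2, `Cc1ccc(Nc2nc(N)nc(Nc3ccc(C)cc3)n2)cc1`, carries an amino group at the same position; in this assay compound 2 gives 57000 nM, the only full number so far in the set, so compound 2 stands alone as the reference point and no step between measured compounds can be drawn. Compound 3, `Cc1ccc(Nc2nc(O)nc(Nc3ccc(C)cc3)n2)cc1`, is next: the change from compound 2 is hydroxy in place of amino on an aromatic carbon. Within the data shown here, with no measured step to lean on, the expectation rests on the reading of compound 2 alone, 57000 nM, and the step from compound 2 to compound 3 is expected to be small, a 1.1-fold higher number from compound 2 to compound 3 (0.02 log units; within the scatter), not clearly beyond the scatter in either direction. Compound 3 is therefore estimated at 60000 nM in this assay, within a range of 25000 nM to 150000 nM, with a real chance that only a limit is reported.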

Compound 3, half-maximal cytotoxic concentration: > 12500 nM
Compound 3: a limit, no number; the forecaster's own chance of this, stated with the estimate: 50%; the middle value does not contradict the limit.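

No step from compound 2 to compound 3 can be read in this assay, because the result for compound 3 is a limit and not a number: the limit of > 12500 nM in this assay, at which 1 of the 3 values shown sits.

The compounds shown leave open whether hydroxy in place of amino on an aromatic carbon changes the half-maximal cytotoxic concentration in either direction.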